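Replacing a Chlorophenyl with a Biphenyl Group

The source may report more compounds than this note shows. Statements on the series, on what has been measured and on what is new or still open speak of the compounds shown alone.

Compound 2 `SC1=NC(n2nc(-c3ccccc3)nc2-c2ccccc2)=CC(c2ccccc2Cl)N1` was tested in a functional assay on the whole organism with Mus musculus as the target, in the maximal electroshock model, with a stated time of 4 h (a lower number here means that less compound is needed, a higher number that more compound is needed for the effect), and gives 300 mg/kg. Compound 1 `SC1=NC(n2nc(-c3ccccc3)nc2-c2ccccc2)=CC(c2ccc(Cl)cc2)N1` gives 300 mg/kg, and the step of no change at the digits printed from compound 1 to compound 2 (within the scatter) shows that moving the chlorine did not matter. Compound 3 `SC1=NC(n2nc(-c3ccccc3)nc2-c2ccccc2)=CC(c2ccc(-c3ccccc3)cc2)N1` carries a different change: 4-phenylphenyl in place of 2-chlorophenyl on a saturated ring carbon. Within the data shown here, no measured step bears on this change, since both known compounds carry a chlorophenyl group. With no guidance from the data, the expected step of no change at the digits printed from compound 2 to compound 3 (within the scatter) is none beyond the scatter, though with wide uncertainty. Compound 3 is therefore estimated at 300 mg/kg, within a range from 100 mg/kg to 600 mg/kg.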

Compound 3, minimum effective dose: 300 mg/kg
Beside the measured number, compound 3's estimate shows no gap at the digits printed; low and high end bracket the measured number.
By their numbers in this assay, from the lowest: compounds 1, 2 and 3 (each within the scatter of the next).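

On the saturated ring carbon, a group with two aromatic rings of carbon only now stands where earlier only chlorophenyl groups stood, and this assay does not separate them: 4-phenylphenyl in place of 2-chlorophenyl gives no change at the digits printed from compound 2 to compound 3 (within the scatter) and phenyl in place of chloro on the aromatic carbon gives no change at the digits printed from compound 1 to compound 3 (within the scatter) for the 4-chlorophenyl partner. Nothing measured here explains this flat result. Going by these compounds, whether an amine or a carboxylic acid on this aromatic ring would shift the dose remains open.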